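The compounds below may be only part of what the source reports. "The series", "measured", "known", "first", "only" and "open" are said of these compounds alone.

Working notes on the series.

Compound 1 `O=C(O)CCc1ccc(C#Cc2cccs2)cc1` is one of two compounds with a number in an in vitro functional assay on 1321-N1 cells for agonist activity at Free fatty acid receptor 1 (Homo sapiens), read by fluorescence, spectrophotometry and calcium flux; a lower number here means a smaller maximal response, a higher number a larger maximal response. In this assay compound 1 gives 97%, and the other measured compound, compound 2 `Cc1c(C#Cc2ccc(CCC(=O)O)cc2)ccnc1Cl`, gives in this assay a reading of 101%. The two values lie within the usual scatter of each other, so neither is set apart from the other on the numbers shown. Both carry the same propanoic acid chain on the shared core and differ only in the aryl group on the triple-bonded carbon.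

Compound 3 `O=C(O)CCc1ccc(C#Cc2cncs2)cc1` has not yet been measured. It differs from compound 1 in one place: 1,3-thiazol-5-yl in place of thiophen-2-yl on a triple-bonded carbon. For the measured compounds named here, no step between two measured compounds covers this kind of exchange, so there is nothing to calibrate the change against. The step expected a number 2 percentage points lower from compound 1 to compound 3 (within the scatter) is small, with no direction beyond the scatter. Compound 3 is therefore estimated to reach 95%, within a range from 78% to 110%.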

Compound 3, largest response reached (reported as efficacy), in percent of the reference or control that the assay uses: 99%
Compound 3: middle estimate off by 4 percentage points, on the low side, within the range that was stated.
By their numbers in this assay, from the lowest: compounds 1, 3 and 2 (each within the scatter of the next).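

In this assay, for the compounds shown here, the exchange of thiophen-2-yl for 1,3-thiazol-5-yl on a triple-bonded carbon gives a number 2 percentage points higher from compound 1 to compound 3 (within the scatter) and is the first one-place step that can be read at this position. Going by these compounds alone, it shows that a five-membered aromatic ring with 2 hetero atoms can take the place of one with 1 hetero atom, with the largest response staying within the scatter, something the earlier compounds offered no step to show. Nothing on hand bears on why the response holds across this exchange.

The compounds shown leave open whether a group of another kind on the triple-bonded carbon, such as a cyclohexyl ring or an aminomethyl group, would move the largest response beyond the scatter. A single step also cannot show whether other five-membered rings, such as a 1,3-oxazol-5-yl group, would behave in the same way.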